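A few compounds are considered here, and "the series" means these few. Any claim that something is new, unique, unknown or untested is made for them only; others in the source may bear on it.

Series notes. The four compounds share one core and differ only in one peripheral group. Compound 1 `COc1ccc(/C=C\C(=O)O)c(OCc2cn(-c3ccccc3F)nn2)c1CC=C(C)C` is recorded in a functional assay on A549 cells (Homo sapiens) for cytotoxicity, read by MTT assay, with a stated time of 24 h (on this read-out higher numbers stand for weaker inhibition and lower numbers for stronger inhibition), as "not determined" (no result reported), and compound 2 `COc1ccc(/C=C\C(=O)O)c(OCc2cn(-c3ccccc3C(=O)N3CCC(O)C3)nn2)c1CC=C(C)C` is recorded in this assay as "not determined" (no result reported). Within the data shown here, compound 3 `COc1ccc(/C=C\C(=O)O)c(OCc2cn(-c3ccccc3I)nn2)c1CC=C(C)C` is the only member with a number: in this assay compound 3 gives 2200 nM, so it stands alone on the scale, with nothing measured beside it to rank it against. Compound 4 `COc1ccc(/C=C\C(=O)O)c(OCc2cn(-c3ccccc3C#N)nn2)c1CC=C(C)C` is the next entry, not yet measured. It differs from compound 3 in one place: cyano in place of iodo on an aromatic carbon, ortho to a large group. Among the measured compounds shown here, no step between two measured compounds exists in this set, so the size of this change cannot be read from any precedent here. With a single measured value as anchor, the expectation for the step from compound 3 to compound 4 in this assay is a modest shift, more likely toward weaker inhibition than stronger, and possibly none beyond the scatter: a 1.6-fold higher number from compound 3 to compound 4 (0.20 log units; within the scatter). On this basis compound 4 is estimated at 3500 nM, with a range from 1200 nM to 10000 nM.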

Compound 4, half-maximal inhibitory concentration: 38600 nM
Beside the measured number, compound 4's estimate is 11-fold (1.04 log units) below it; measured number above the stated range.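

In this assay this position proves sensitive: cyano in place of iodo on an aromatic carbon, ortho to a large group, gives an 18-fold higher number from compound 3 to compound 4 (1.24 log units; beyond the scatter) and so moves the series clearly toward weaker inhibition. Among these compounds, this is the first readable step, and it shows that a single exchange, 2-iodophenyl to 2-cyanophenyl, is enough to shift the read-out well beyond the scatter, which the lone value of compound 3 could not show. No measurement available here bears on the reason for this shift.

Steps involving compound 1 or compound 2 cannot be read, as neither has a number. On these data alone, whether an amine or a methoxy group at this position would lie nearer compound 3 or compound 4 remains open.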